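The compounds below may be only part of what the source reports. "The series", "measured", "known", "first", "only" and "open" are said of these compounds alone.

Compound 1 `CN(Cc1ccccc1)S(=O)(=O)c1ccc(NC(=O)NCc2ccncc2)cc1` is a urea that carries a sulfonamide. In an assay on isolated protein for activation of Nicotinamide phosphoribosyltransferase (Homo sapiens) (a higher number here means that more compound is needed for the effect, a lower number that less compound is needed), compound 1 gives 23 nM, the lowest of the three numbers recorded so far, although compound 2 `O=C(NCc1cn[nH]c1)Nc1ccc(S(=O)(=O)c2ccccc2)cc1` sits within the usual scatter of it with 28 nM, so the two cannot be ranked. Compound 3 `CCOC(=O)c1ccc(NC(=S)NCc2ccncc2)cc1`, a thiourea with an ester in place of the sulfonyl group, gives 9770 nM, far weaker than either. Compound 4 `CCN(C1CCCC1)S(=O)(=O)c1ccc(NC(=O)NCc2ccncc2)cc1` has not yet been measured. It differs from compound 1 in one place: cyclopentyl(ethyl)amino in place of benzyl(methyl)amino on a sulfonyl sulfur. Among the compounds with values here, no measured pair isolates a change of this kind, so the expectation leans on what is already seen: compound 2 gives 28 nM, close to compound 1, which hints that the group on the sulfonyl sulfur is not what separates the potent compounds from compound 3. The step is therefore expected to be small, a 1.7-fold higher number from compound 1 to compound 4 (0.24 log units; within the scatter), possibly a modest loss but near the scatter. Compound 4 is estimated at 40 nM, with a range from 12 nM to 130 nM.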

Compound 4, half-maximal effective concentration: 60 nM
Estimate against measurement, compound 4: 1.5-fold (0.18 log units) below; the range from low to high includes it.
By their numbers in this assay, from the lowest: compounds 1 and 2 (each within the scatter of the next); then compound 4; then compound 3.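

Within the data shown here, this is the first measured step at this position, and in this assay it gives a 2.6-fold higher number from compound 1 to compound 4 (0.42 log units; beyond the scatter), a modest loss. The group on the sulfonyl sulfur therefore does affect the number, yet a five-membered non-aromatic ring in cyclopentyl(ethyl)amino still leaves compound 4 active at 60 nM, without the six-membered aromatic ring of benzyl(methyl)amino. No measurement shown here explains the loss.

The change replaces the ring and both chains on the nitrogen at once, so these compounds cannot show which part accounts for the step. Also open, as far as these compounds go, is how groups such as dimethylamino or morpholine would compare at this position, or whether a benzyl(ethyl)amino group would separate the effect of the ring from that of the chain.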